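Swapping the amide-side ring of a shared core

The source may hold more compounds than are shown below. What is called first, only, known or untested is meant among the compounds shown, and "the series" means these compounds.

Compound 3 `O=C(COc1ccc(/C=C2\SC(=O)NC2=O)cc1)Nc1nc2ccccc2s1` was tested in a functional assay on KB cells (Homo sapiens) for cytotoxicity, read by sulforhodamine B assay, with a stated time of 48 h; on this read-out higher numbers stand for weaker inhibition of growth and lower numbers for stronger inhibition of growth. In this assay compound 3 gives < 100000 nM, which is a limit of the assay rather than a number. Compound 1 `Cc1cnc(NC(=O)COc2ccc(/C=C3\SC(=O)NC3=O)cc2)s1` in this assay gives < 100000 nM, again a limit. Compound 2 `CCCCC1=NC2(CCCC2)C(=O)N1C(=O)COc1ccc(/C=C2/SC(=O)NC2=O)cc1` gives < 100000 nM, a limit as well. All three measured values therefore sit at the same limit (the limit of < 100000 nM in this assay, at which 3 of the 3 values shown sit), so the step that the two limits leave unreadable from compound 1 to compound 3 cannot be read. Compound 4 `O=C(COc1ccc(/C=C2\SC(=O)NC2=O)cc1)Nc1ncc([N+](=O)[O-])s1` differs from compound 3 in one place: 5-nitro-1,3-thiazol-2-yl in place of 1,3-benzothiazol-2-yl on an amide-type nitrogen. Among the measured compounds shown here, no measured step shows how such an exchange shifts growth inhibition, so for compound 4 the expected result is once more a limit, estimated at 100000 nM with a range from 20000 nM to 300000 nM. That corresponds to an expected step of a number no lower from compound 3 to compound 4 (the limit leaves the size open).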

Compound 4, concentration for 50% growth inhibition: < 100000 nM
Compound 4 ended at the assay's limit; the forecaster's own chance of this, stated with the estimate: 80%; the middle value lies on the limit itself.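

Compound 4, like compound 1 and compound 3, ends at a limit rather than a number, so no step among them can be read: the limit of < 100000 nM in this assay, at which 4 of the 4 values shown sit.

The compounds shown leave open whether exchanging the ring on the amide nitrogen changes growth inhibition at all in this assay.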